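The compounds below may be only part of what the source reports. "The series", "measured", "known", "first", "only" and "open" are said of these compounds alone.

Compound 1 `COc1ccc(-c2nc3sc(-c4ccccc4)cn3n2)cc1` gives 21%
Compound 2 `Clc1ccc(-c2cn3nc(-c4ccccc4)nc3s2)cc1` gives 25%

Going by the values given here, in a functional assay on U-251 cells (Homo sapiens) for inhibition, read by sulforhodamine B assay, with a stated time of 48 h, tested at 10 uM (on this read-out higher numbers stand for more inhibition of growth at the one concentration tested and lower numbers for less inhibition of growth), compound 2 stands at 25% and so sits level, within the scatter, with compound 1 at 21% on the only two numbers available. Compound 3 `c1ccc(-c2nc3sc(-c4ccccc4)cn3n2)cc1` has hydrogen in place of chloro on an aromatic carbon and is still unmeasured. Among the compounds with values here, no measured pair shows this change alone, so no step beyond the scatter is expected in this assay here. The estimated a number 4 percentage points lower from compound 2 to compound 3 (within the scatter) is small and points slightly downward. For compound 3 the expected value is 21% within an estimated range from 9% to 33% in this read-out.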

Compound 3, percent growth inhibition at one concentration: 6%
For compound 3 the middle estimate is 15 percentage points above the measured one; measured number below the stated range.
By their numbers in this assay, from the lowest: compound 3; then compounds 1 and 2 (each within the scatter of the next).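

In this assay, the change from 4-chlorophenyl to phenyl gives a number 19 percentage points lower from compound 2 to compound 3 (beyond the scatter), and removing the methoxy group gives a number 15 percentage points lower from compound 1 to compound 3 (beyond the scatter). Compound 3, with neither group, thus shows that the modest growth inhibition of compound 1 and compound 2 depends on carrying such a group, something their level values alone could not show. Nothing measured here explains this loss. Going by these compounds, whether an amine, a carboxylic acid or a fluoro group in place of chloro would keep or raise the inhibition remains open. So does whether chloro and methoxy together would add to it.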